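The source may report more compounds than this note shows. Statements on the series, on what has been measured and on what is new or still open speak of the compounds shown alone.

Measured in a functional assay on HL-60 cells (Homo sapiens) for cytotoxicity, read by MTT assay, with a stated time of 72 h; a higher number here means a weaker inhibitor, a lower number a stronger inhibitor:
- compound 1 `COC(=O)c1sc2c(C)cccc2c1Nc1cc(OC)c(OC)c(OC)c1`: 4270 nM
- compound 2 `CCOC(=O)c1sc2cccc(C)c2c1Nc1cc(OC)c(OC)c(OC)c1`: 7390 nM
- compound 3 `COC(=O)c1sc2ccccc2c1Nc1cc(OC)c(OC)c(OC)c1`: 1540 nM

Compound 3 has the lowest number of the three in this assay, so it is the strongest inhibitor measured so far in the series. Compound 4 `COC(=O)c1sc2cccc(C)c2c1Nc1cc(OC)c(OC)c(OC)c1` has not yet been measured. It keeps the methyl ester of compound 3 and has methyl in place of hydrogen on an aromatic carbon.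

For the measured compounds named here, only one measured step bears directly on this change: a 2.8-fold lower number from compound 1 to compound 3 (0.44 log units; beyond the scatter). That step removes a methyl group from a different aromatic carbon, so it serves as a guide only when read in reverse. Compound 2 offers a second reference, with its methyl on the same carbon as in compound 4 but an ethyl ester in place of the methyl ester. Going by the values given here, compound 2 gives 7390 nM, and no measured step separates the effect of its ester from that of its methyl group.

Both reference compounds have higher numbers than compound 3, so a modest rise beyond the scatter is expected. The expected change is a 2.9-fold higher number from compound 3 to compound 4 (0.47 log units; beyond the scatter). Compound 4 is estimated at 4500 nM, with an expected range of 1900 nM to 10000 nM.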

Compound 4, half-maximal inhibitory concentration: 3390 nM
Estimate against measurement, compound 4: 1.3-fold (0.12 log units) above; the measured number falls inside the stated range.
By their numbers in this assay, from the lowest: compound 3; then compounds 4, 1 and 2 (each within the scatter of the next, the first and the last beyond it).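

In this assay the methyl group on this aromatic carbon can now be read alone, as a 2.2-fold higher number from compound 3 to compound 4 (0.34 log units; beyond the scatter) shows, and the ester can be read alone at the same time, as a 2.2-fold lower number from compound 2 to compound 4 (0.34 log units; beyond the scatter) shows, so the ethyl ester and the methyl group each carry a modest step of their own. Compound 1 at 4270 nM and compound 4 at 3390 nM lie within the scatter of each other, so these two placements of the methyl group on the six-membered aromatic ring cannot be told apart in this assay, and each stands beyond the scatter from the unsubstituted compound 3. Nothing in the data gives a reason for either new step.

Open, on these data alone, is whether the rise at this carbon belongs to methyl in particular or would also follow a fluorine, a chlorine or a methoxy group there. Also open, as far as these compounds go, is how this assay responds when the ester gives way to a carboxylic acid or an amide, or when the ester chain grows longer than ethyl.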